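A methyl in place of chloro in compound 1

A few compounds are considered here, and "the series" means these few. Any claim that something is new, unique, unknown or untested is made for them only; others in the source may bear on it.

In a functional assay on DU-145 cells (Homo sapiens) for cytotoxicity, read by MTT assay (on this read-out lower numbers stand for stronger inhibition and higher numbers for weaker inhibition), compound 1 `COc1ccc2cc([C@H](C)c3nnc(SCc4ccc(Cl)cc4)n3-c3ccc(F)cc3)ccc2c1` gives 57400 nM and compound 2 `COc1ccc2cc([C@H](C)c3nnc(SCc4c(C)cc(C)cc4C)n3-c3cccc(Cl)c3)ccc2c1` gives 93300 nM so the two numbers sit within the usual scatter of each other and compound 1 holds no distinct place between them. For compound 3 `COc1ccc2cc([C@H](C)c3n[nH]c(=S)n3-c3cccc(Cl)c3)ccc2c1` the entry reads "not determined" (no result reported) and no number was reported. Compound 4 `COc1ccc2cc([C@H](C)c3nnc(SCc4ccc(C)cc4)n3-c3ccc(F)cc3)ccc2c1` is still unmeasured. It carries methyl in place of the chloro of compound 1 on an aromatic carbon, para to a large group (methyl in place of chloro on an aromatic carbon), which turns 4-chlorobenzyl into 4-methylbenzyl. Among the compounds with values here, no two measured compounds differ in one place only, so the data offer no direct guide to this change. In this assay no step beyond the scatter is expected, in either direction. The closest reference is compound 1 at 57400 nM and the estimate stays near it. The expected move (a 1.0-fold higher number from compound 1 to compound 4 (0.02 log units; within the scatter)) is accordingly small. Compound 4 is estimated at 60000 nM with an expected range from 30000 nM to 110000 nM as its likely span.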

Compound 4, half-maximal inhibitory concentration: 44300 nM
For compound 4 the middle estimate is 1.4-fold (0.13 log units) above the measured one; the range from low to high includes it.
By their numbers in this assay, from the lowest: compounds 4, 1 and 2 (each within the scatter of the next, the first and the last beyond it).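

In this assay, methyl in place of chloro on an aromatic carbon, para to a large group, gives a 1.3-fold lower number from compound 1 to compound 4 (0.11 log units; within the scatter). Within the data shown here, this is the first direct reading of a single change, which the earlier compounds, differing in more than one place, could not give. The step lies within the scatter, so on this read-out 4-chlorobenzyl and 4-methylbenzyl cannot be told apart at this position, and no measured evidence accompanies the result to explain it.

The compounds shown leave open whether a group of another kind at this spot, such as an amine or a carboxylic acid, would shift the number beyond the scatter. They also leave open whether the same exchange would read alike on a different core.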